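Methylating the Amide Nitrogen of Compound 2

A few compounds are considered here, and "the series" means these few. Any claim that something is new, unique, unknown or untested is made for them only; others in the source may bear on it.

The series contains two measured compounds and one awaiting measurement. Compound 1 `CC1(C)C[C@H](O)C[C@](C)(CNC(=O)c2cc(Cl)ccc2O)C1` and compound 2 `O=C(Nc1ccccc1)C1(c2ccccc2)CCCC1` share no common scaffold and are not joined by a single-point step. In an ADME assay on MDCK cells (Canis lupus familiaris) for cytotoxicity (on this read-out lower numbers stand for higher toxicity in this test and higher numbers for lower toxicity in this test), compound 1 reaches only the assay limit of > 50000 nM. In this assay compound 2 likewise reaches only the assay limit of > 100000 nM. Compound 2 thus stands at the upper ceiling of this assay, one of the two limits shown (the limit of > 100000 nM in this assay, at which 1 of the 2 values shown sits), with the other value sitting at a separate limit (the limit of > 50000 nM in this assay, at which 1 of the 2 values shown sits). Compound 3 `CN(C(=O)C1(c2ccccc2)CCCC1)c1ccccc1` differs from compound 2 by methyl in place of hydrogen on an amide-type nitrogen. For the measured compounds named here, no measured step resembles this change. Compound 3 is expected to remain at or near the limit in this assay, with an estimated step of a number no higher from compound 2 to compound 3 (the limit leaves the size open) that stays within the scatter. Compound 3 is therefore estimated at 100000 nM, between 50000 nM and 200000 nM.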

Compound 3, half-maximal cytotoxic concentration: 52000 nM
Estimate against measurement, compound 3: 1.9-fold (0.28 log units) above, and the stated range covers the measured number.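

Compound 3 is the only compound shown whose read-out is a number and not a limit, so methyl in place of hydrogen on an amide-type nitrogen gives the one step in this series that can be read: in this assay, the change gives an at least 1.9-fold lower number from compound 2 to compound 3 (0.28 log units; that floor lies within the scatter). For the compounds shown here, that floor alone does not establish a real change at this position, and the data show only that the change does not carry the number beyond the scatter of the limit. The true size of the step stays open upward, since the starting value of compound 2 is itself a limit: the limit of > 100000 nM in this assay, at which 1 of the 3 values shown sits.

The compounds shown leave open how an ethyl group, or a longer chain ending in an amine, on this nitrogen would read in this assay. They also leave open whether any group at this position moves the number beyond the scatter.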